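The source may hold more compounds than are shown below. What is called first, only, known or untested is meant among the compounds shown, and "the series" means these compounds.

Measured so far:
compound 1, `CCCc1ccc(-c2cc(=O)c3c(o2)C(CC)(CC)C(=O)C(CC)=C3O)cc1` — in a functional assay on KB cells (Homo sapiens) for antiproliferative activity, read by sulforhodamine B assay, with a stated time of 3 days (a lower number here means that less compound is needed, a higher number that more compound is needed for the effect), compound 1 reaches only the limit > 53 uM, a limit rather than a number.
compound 2, `CCC1=C(O)c2c(oc(-c3ccccc3C)cc2=O)C(CC)(CC)C1=O` — compound 2 gives 40.9 uM.
compound 3, `CCC1=C(O)c2c(oc(-c3ccccc3OC)cc2=O)C(CC)(CC)C1=O` — compound 3 gives 40.8 uM.

Compound 3 stands lowest of the two numbers shown, with compound 2 closest to it; the gap between them is within the scatter. Compound 4, `CCC1=C(O)c2c(oc(-c3ccc(OC)c(F)c3)cc2=O)C(CC)(CC)C1=O`, differs from compound 3 in one place: 3-fluoro-4-methoxyphenyl in place of 2-methoxyphenyl on an aromatic carbon. The steps measured so far, an at least 1.2-fold lower number from compound 1 to compound 2 (0.11 log units; that floor lies within the scatter), an at least 1.2-fold lower number from compound 1 to compound 3 (0.11 log units; that floor lies within the scatter) and a 1.0-fold lower number from compound 2 to compound 3 (0.00 log units; within the scatter), are all within the scatter, so swapping one small substituted phenyl group for another has so far not moved the number. The step of a 1.0-fold lower number from compound 3 to compound 4 (0.01 log units; within the scatter) is therefore expected to stay within the scatter. Compound 4 is estimated at 40 uM, between 15 uM and 100 uM.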

Compound 4, concentration for half-maximal effect: 26.7 uM
For compound 4 the middle estimate is 1.5-fold (0.18 log units) above the measured one; low and high end bracket the measured number.
By their numbers in this assay, from the lowest: compounds 4, 3 and 2 (each within the scatter of the next). At a limit, above all of these: compound 1.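

In this assay, within the data shown here, the first phenyl group here to carry fluorine, at this place next to the ring oxygen, stays within the scatter of the earlier groups (a 1.5-fold lower number from compound 3 to compound 4 (0.18 log units; within the scatter)) and (a 1.5-fold lower number from compound 2 to compound 4 (0.19 log units; within the scatter)). A phenyl group with two substituents therefore gives a number no different, beyond the scatter, from those of compounds 2 and 3 with one. The comparison with compound 1 (an at least 1.9-fold lower number from compound 1 to compound 4 (0.29 log units; that floor lies within the scatter)) gives only a floor, and it rests on a limit: the limit of > 53 uM in this assay, at which 1 of the 4 values shown sits.

From the compounds shown here alone, whether an amine or a carboxylic acid on this phenyl ring would take the number beyond the scatter remains open. So does the effect of a longer chain on the shared core.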